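This account rests on a few compounds, and the source may have more. Where it says the series, first, only, none or still open, it means among the compounds named here.

Working notes on the series. Compound 1 `COCCNC(=C\C(=O)/C=C/c1ccc(O)cc1)/C=C/c1ccc(O)cc1` and compound 3 `COCCCNC(=C\C(=O)/C=C/c1ccc(O)cc1)/C=C/c1ccc(O)cc1` are built on one core; compound 2 `COCCNC(=C\C(=O)/C=C/c1ccc(O)c(OC)c1)/C=C/c1ccc(O)c(OC)c1` and the not yet measured compound 4 `COCCCNC(=C\C(=O)/C=C/c1ccc(O)c(OC)c1)/C=C/c1ccc(O)c(OC)c1` are built on another. How the core of compound 2 differs from the core of compound 1 is not broken down here.

In an ADME assay on CHO-K1 cells (Cricetulus griseus) for activation, read by fluorescence, tested at 1 uM (a higher number here means a weaker effect of the compound at the concentration tested, a lower number a stronger effect), compound 1 gives 82.5%. In this assay compound 3 gives 99.8%, and compound 2 gives 94%. The change from compound 1 to compound 3, (methoxymethyl in place of methoxy on a saturated chain carbon, two bonds along the chain from an amine nitrogen), made a step of a number 17.3 percentage points higher from compound 1 to compound 3 (beyond the scatter). The reading of compound 2 sits higher than that of compound 1, beyond the scatter, and within the scatter of the reading of compound 3, so no order between compound 2 and compound 3 is claimed.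

Going by the values given here, the change from compound 2 to compound 4, (methoxymethyl in place of methoxy on a saturated chain carbon, two bonds along the chain from an amine nitrogen), is the same change as the one from compound 1 to compound 3, now made on the other core; it occurs twice among the compounds here. For compound 4 a step of a number 6 percentage points higher from compound 2 to compound 4 (within the scatter) in this assay is expected, smaller than the earlier step, because compound 2 already reads 94% and lies close to the top of the range this read-out usually covers, leaving little room for a rise of the earlier size. Compound 4 is therefore estimated at 100%, with a range from 92% to 110%.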

Compound 4, a percentage reported as activity, at one concentration (the size of the read-out at that concentration, not a potency): 98.3%
Compound 4: the middle estimate sits 1.7 percentage points above what was measured; low and high end bracket the measured number.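

On the core of compound 2, methoxymethyl in place of methoxy gives in this assay a number 4.3 percentage points higher from compound 2 to compound 4 (within the scatter), so on this core taken alone no effect of the change is established. Set beside the step on the core of compound 1, this result gives no ground for saying that the two cores respond differently: the same change on two cores in this assay, a number 17.3 percentage points higher (beyond the scatter) from compound 1 to compound 3 and a number 4.3 percentage points higher (within the scatter) from compound 2 to compound 4, 13 percentage points apart, within the scatter of two such steps This does not show that the change carries over with a fixed size, since the step on one core is beyond the scatter and the step on the other is within it, and a single pair on each core can neither confirm nor rule out a real difference between them.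

The compounds shown leave open whether the step would hold on a third core, and how the reading would respond to other groups at the end of the same chain, such as a longer chain, a hydroxyl in place of the methoxy, or an amine. They also give a single read-out at one concentration, which offers no potency and leaves open how the pairs would compare across a range of concentrations.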